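Adding 1-hydroxyethyl to compound 3

The source may hold more compounds than are shown below. What is called first, only, known or untested is meant among the compounds shown, and "the series" means these compounds.

In an ADME assay on L1210 cells (Mus musculus) for cytotoxicity, with a stated time of 48 h (on this read-out higher numbers stand for weaker inhibition and lower numbers for stronger inhibition), the measured compounds read as follows:
- compound 1 `C=C1[C@H](C)CCC[C@]1(C)CC/C(C)=C/CC1=C(O)C(=O)C=C(N[C@@H](C(=O)O)C(C)C)C1=O` gives 3.4 ug/mL
- compound 2 `C=C1[C@H](C)CCC[C@]1(C)CC/C(C)=C/CC1=C(O)C(=O)C=C(N[C@@H](C(=O)O)[C@H](C)O)C1=O` gives 4.6 ug/mL
- compound 3 `C=C1[C@H](C)CCC[C@]1(C)CC/C(C)=C/CC1=C(O)C(=O)C=C(NCC(=O)O)C1=O` gives 4 ug/mL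

Compound 3 has no separate rank among these three values. Its two steps are small and within the scatter: a 1.2-fold higher number from compound 1 to compound 3 (0.07 log units; within the scatter) and a 1.2-fold lower number from compound 2 to compound 3 (0.06 log units; within the scatter) in this comparison.

Compound 3 carries hydrogen on a saturated chain carbon bound to an amine nitrogen and a carbonyl carbon. Compound 4 `C=C1[C@H](C)CCC[C@]1(C)CC/C(C)=C/CC1=C(O)C(=O)C=C(N[C@H](C(=O)O)[C@H](C)O)C1=O` has 1-hydroxyethyl in place of that hydrogen 1-hydroxyethyl in place of hydrogen on a saturated chain carbon bound to an amine nitrogen and a carbonyl carbon and keeps the rest of the structure of compound 3.

The closest evidence is the exchange of these two groups in the opposite sense, a 1.2-fold lower number from compound 2 to compound 3 (0.06 log units; within the scatter) and it stays within the scatter. The steps involving isopropyl at that carbon are equally small: a 1.4-fold higher number from compound 1 to compound 2 (0.13 log units; within the scatter) and a 1.2-fold higher number from compound 1 to compound 3 (0.07 log units; within the scatter) in this assay as well. Within the data shown here, the data hold no separate step for the defined stereocentre of the entering group, so the range is kept wide. The expected step is a 1.1-fold higher number from compound 3 to compound 4 (0.04 log units; within the scatter) and no change beyond the scatter is expected. For compound 4 the estimated value is 4.4 ug/mL with an expected range from 2.4 ug/mL to 8 ug/mL in this assay when measured.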

Compound 4, half-maximal inhibitory concentration: > 10 ug/mL
Compound 4 gave a limit, no number; the forecaster's own chance of this, stated with the estimate: 2%; middle value at least 2.2-fold (0.35 log units) from the limit.
By their numbers in this assay, from the lowest: compounds 1, 3 and 2 (each within the scatter of the next). At a limit, above all of these: compound 4.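

In this assay compound 4 gives > 10 ug/mL, which is a limit and not a number. Until now, hydrogen, isopropyl and 1-hydroxyethyl on the saturated chain carbon bound to an amine nitrogen and a carbonyl carbon had stayed within the scatter of one another, whereas an at least 2.5-fold higher number from compound 3 to compound 4 (0.39 log units; beyond the scatter) and an at least 2.9-fold higher number from compound 1 to compound 4 (0.46 log units; beyond the scatter) are steps beyond it, so this position is not indifferent to what it carries. Since compound 2 also carries 1-hydroxyethyl there and stayed within the scatter of compound 3, the entering group alone does not account for the result, and an at least 2.1-fold higher number from compound 2 to compound 4 (0.33 log units; beyond the scatter) ties the change to a single stereocentre at a saturated chain carbon because of this: the fact that compounds 2 and 4 differ only in the configuration as drawn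

The compounds shown leave open how far the true value of compound 4 lies from its limit, so the full size of these steps cannot be read. They also leave open whether the same inversion at that stereocentre would have a like effect with isopropyl, with a longer chain or with an amine on that carbon.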